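The source may report more compounds than this note shows. Statements on the series, on what has been measured and on what is new or still open speak of the compounds shown alone.

Measured so far in a functional assay on HCT-116 cells (Homo sapiens) for antiproliferative activity, read by MTT assay, with a stated time of 72 h; a higher number here means a weaker inhibitor, a lower number a stronger inhibitor:
- Compound 1 `CC(=O)c1nc([N+](=O)[O-])c(Sc2c(Cl)cccc2Cl)s1` gives 19300 nM
- Compound 2 `CCCC(=O)OC(C)c1nc([N+](=O)[O-])c(Sc2c(Cl)cncc2Cl)s1` gives 11700 nM

In this assay compound 2 gives 11700 nM and so stands within the scatter of compound 1, with no order to be read between the two. Among the measured compounds shown here, no pair of measured compounds differs in one place only, so the data hold no direct guide to the next change.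

Compound 3 `CC(O)c1nc([N+](=O)[O-])c(Sc2c(Cl)cncc2Cl)s1` follows from compound 2 with hydrogen in place of propylcarbonyl on an oxygen on a saturated carbon so that (propylcarbonyl)oxy becomes hydroxy. Without a measured step for this change, only a small rise in the number in this assay is expected, pointing to a slightly weaker inhibitor, with nothing clearly beyond the scatter. The expected size is a 1.3-fold higher number from compound 2 to compound 3 (0.11 log units; within the scatter) and this remains an estimate. For the measured compounds named here, it leans on compound 2 at 11700 nM and on compound 1 at 19300 nM as the only numbers known. For compound 3 the estimated value is 15000 nM with an expected range from 5000 nM to 45000 nM in this assay.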

Compound 3, half-maximal inhibitory concentration: 18600 nM
Compound 3: the middle estimate sits 1.2-fold (0.09 log units) below what was measured, within the range that was stated.
By their numbers in this assay, from the lowest: compounds 2, 3 and 1 (each within the scatter of the next).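

In this assay, taking propylcarbonyl off the oxygen on the saturated carbon, so that 1-((propylcarbonyl)oxy)ethyl becomes 1-hydroxyethyl, gives a 1.6-fold higher number from compound 2 to compound 3 (0.20 log units; within the scatter). This is the first pair among the compounds shown that differs in one place only, and so the first direct reading of this position: the whole propylcarbonyl group can be replaced by hydrogen without a step that stands clear of the scatter, so this assay does not separate the free hydroxy from its propylcarbonyl-bearing form. Nothing available accounts for this result or tells what either group does in the cells.

The compounds shown leave open whether a longer chain on this oxygen, or an amine in place of the hydroxy, would give a step beyond the scatter. They also leave open whether the same change would read alike on a compound otherwise like compound 1, which differs from compound 2 and compound 3 in more than one place and so offers no direct comparison with either.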